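The source may report more compounds than this note shows. Statements on the series, on what has been measured and on what is new or still open speak of the compounds shown alone.

The measured compounds, all tested in a functional assay on WM 266-4 cells (Homo sapiens) for antiproliferative activity, read by MTT assay, with a stated time of 24 h; on this read-out higher numbers stand for weaker inhibition of growth and lower numbers for stronger inhibition of growth:
compound 1, `COc1ccc(C2=NN(C(=O)c3ccc(C)nc3Cl)C(c3ccc(OC)cc3)C2)cc1`, giving 5740 nM;
compound 2, `COc1ccc(C2=NN(C(=O)c3cccnc3Cl)C(c3ccc(OC)cc3)C2)cc1`, giving 4350 nM;
compound 3, `COc1ccc(C2=NN(C(=O)c3ccc(C)nc3Cl)C(c3ccc(Br)cc3)C2)cc1`, giving 8470 nM.

Compound 1 and compound 2 share a core and differ in one group: hydrogen in place of methyl on an aromatic carbon. In this assay that change gave a 1.3-fold lower number from compound 1 to compound 2 (0.12 log units; within the scatter), a step too small to separate the two compounds. Compound 3 differs from compound 1 on the other ring: bromo in place of methoxy on an aromatic carbon. That change gave a 1.5-fold higher number from compound 1 to compound 3 (0.17 log units; within the scatter), again too small to tell the two apart. Compound 4, `COc1ccc(C2=NN(C(=O)c3cccnc3Cl)C(c3ccc(Br)cc3)C2)cc1`, has not yet been measured. It differs from compound 3 in exactly the same way that compound 2 differs from compound 1: hydrogen in place of methyl on an aromatic carbon. Given the earlier step of a 1.3-fold lower number from compound 1 to compound 2 (0.12 log units; within the scatter), the corresponding change on the core of compound 3 is expected to give a 1.3-fold lower number from compound 3 to compound 4 (0.11 log units; within the scatter). On that basis compound 4 is expected to give about 6500 nM in this assay, with a likely range from 3000 nM to 14000 nM.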

Compound 4, concentration for 50% growth inhibition: 3050 nM
Estimate against measurement, compound 4: 2.1-fold (0.33 log units) above; measured number inside the range.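

In this assay, hydrogen in place of methyl, which turns the 2-chloro-6-methylpyridin-3-yl group into 2-chloropyridin-3-yl, gave a 2.8-fold lower number from compound 3 to compound 4 (0.44 log units; beyond the scatter), and this step agrees with the earlier one on the other core: the same change on two cores in this assay, a 1.3-fold lower number (0.12 log units; within the scatter) from compound 1 to compound 2 and a 2.8-fold lower number (0.44 log units; beyond the scatter) from compound 3 to compound 4, 2.1-fold (0.32 log units) apart, within the scatter of two such steps Bromo in place of methoxy gave a 1.4-fold lower number from compound 2 to compound 4 (0.15 log units; within the scatter), and this step also agrees with its earlier counterpart: the same change on two cores in this assay, a 1.5-fold higher number (0.17 log units; within the scatter) from compound 1 to compound 3 and a 1.4-fold lower number (0.15 log units; within the scatter) from compound 2 to compound 4, 2.1-fold (0.32 log units) apart, within the scatter of two such steps Both changes are therefore consistent with carrying over from one core to the other, but two cores per change are too few to establish a general rule, and these data do not show that the methyl change really has a larger effect on the core of compound 3.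

The compounds shown leave open how other groups would behave next to the ring nitrogen, such as an amine or a longer chain like propyl. They also leave open whether a carboxylic acid in place of the bromo would follow the same pattern.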